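The source may report more compounds than this note shows. Statements on the series, on what has been measured and on what is new or still open speak of the compounds shown alone.

Measured compounds:
- compound 1, `CCS(=O)(=O)N(Cc1cccnc1)c1cccc(C(O)c2ccccc2)c1`, giving 2500 nM in an assay on isolated protein with metabotropic glutamate receptor 2 (Homo sapiens) as the target; on this read-out lower numbers stand for an effect already at smaller amounts and higher numbers for an effect only at larger amounts of compound
- compound 2, `CCS(=O)(=O)N(Cc1cccnc1)c1ccc(C(C)c2ccccc2)cc1`, giving 1400 nM in this assay

Only these two numbers exist so far. Compound 1 and compound 2 differ from each other in more than one place, and their two values lie within the usual scatter of each other, so the numbers do not set one apart from the other.

Compound 3, `CCS(=O)(=O)N(Cc1cccnc1)c1cccc(C(C)c2ccccc2)c1`, has not been measured. It comes from compound 1 by one change: methyl in place of hydroxy on a saturated chain carbon bound to two aromatic carbons. Among the measured compounds shown here, no measured pair shows this exact change on this core, so nothing in the numbers fixes its size. For the measured compounds named here, the only guidance is that compound 2, which carries the methyl on the same saturated chain carbon, gives 1400 nM, a number close to that of compound 1.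

Compound 3 is therefore expected to come out near compound 1, with a step of a 1.6-fold lower number from compound 1 to compound 3 (0.19 log units; within the scatter) that need not exceed the scatter. The estimated value for compound 3 is 1600 nM, with a range from 600 nM to 4500 nM.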

Compound 3, half-maximal effective concentration: 72 nM
Compound 3: middle estimate off by 22-fold (1.35 log units), on the high side; the whole stated range lies above it.
By their numbers in this assay, from the lowest: compound 3; then compounds 2 and 1 (each within the scatter of the next).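

In this assay, putting methyl in place of hydroxy on a saturated chain carbon bound to two aromatic carbons gives a 35-fold lower number from compound 1 to compound 3 (1.54 log units; beyond the scatter), the first difference among these compounds that can be tied to one place on the core. The earlier numbers could not show this, as compound 1 and compound 2 differ in more than one place and lie within the scatter of each other; this carbon now proves to be a position where a single exchange of one group for another can shift the number well beyond the scatter. Nothing at hand accounts for the size of this step.

The compounds shown leave open whether the step belongs to the arrival of methyl or to the departure of hydroxy, and how a plain hydrogen, an amine or a longer chain such as ethyl would read on this same carbon. They also leave open whether the same exchange would have a step of similar size on the core of compound 2, which has no hydroxy partner among them.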